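Double-bond configuration: compound 1 to compound 3

The source may hold more compounds than are shown below. What is called first, only, known or untested is meant among the compounds shown, and "the series" means these compounds.

For the measured compounds named here, in a functional assay on MCF7 cells (Homo sapiens) for inhibition, read by XTT assay, with a stated time of 48 h (on this read-out lower numbers stand for stronger inhibition and higher numbers for weaker inhibition), compound 1 (`CC(=O)OC/C(=C\c1ccc(Cl)cc1Cl)C(=O)c1ccccc1`) gives 8700 nM, the only numerical value so far. Compound 2 (`COc1ccc(C(=O)/C(=C/c2c(F)c(F)c(F)c(F)c2F)CCOC(C)=O)cc1`) reads > 100000 nM, which is a limit of the assay and not a number. Compound 3 (`CC(=O)OC/C(=C/c1ccc(Cl)cc1Cl)C(=O)c1ccccc1`) has the same atoms and bonds as compound 1 and differs only in configuration as drawn (the two compounds have the same atoms and bonds and differ only in configuration as drawn: 1 of 1 stereo elements differ; a double bond is drawn E in compound 1 and Z in compound 3): a double bond is drawn E in compound 1 and Z in compound 3. Going by the values given here, no measured pair isolates this change, so neither the size nor the direction of the step is established in this assay. A modest loss of inhibition is tentatively expected, and a result within the usual scatter would not be surprising. The estimated change is a 1.7-fold higher number from compound 1 to compound 3 (0.24 log units; within the scatter). For compound 3 the expected value is 15000 nM, with an estimated range from 4000 nM to 60000 nM.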

Compound 3, half-maximal inhibitory concentration: 31700 nM
Beside the measured number, compound 3's estimate is 2.1-fold (0.32 log units) below it, and the stated range covers the measured number.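

In this assay, for the compounds shown here, the change of the double bond from E to Z gives a 3.6-fold higher number from compound 1 to compound 3 (0.56 log units; beyond the scatter) and is the first step that isolates one change. Configuration at this double bond therefore registers in the read-out beyond the scatter, and of this pair compound 1, drawn E, is the stronger inhibitor. The step can be assigned to configuration alone, with no other structural change in the pair: the fact that compounds 1 and 3 differ only in the configuration as drawn.

Compound 2 reads > 100000 nM, which is a limit of the assay and offers no number against which a step could be read. Open, as far as these compounds go, is whether the same step keeps its direction and size on other aryl groups, or when a carboxylic acid or an amine stands in place of the acetate ester.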